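Halogen change on the urea aryl of a glucagon receptor series

The source may hold more compounds than are shown below. What is called first, only, known or untested is meant among the compounds shown, and "the series" means these compounds.

Measured compounds:
Compound 1 `Cc1cc(C)cc(NC(=O)N(Cc2ccc(C(=O)NC[C@@H](O)C(=O)O)cc2)[C@H]2CC[C@H](C(C)(C)C)CC2)c1` gives 27 nM in an in vitro assay on BHK cells for binding affinity to Glucagon receptor (Homo sapiens); a higher number here means a weaker inhibitor, a lower number a stronger inhibitor.
Compound 2 `O=C(NC[C@@H](O)C(=O)O)c1ccc(CN(C(=O)Nc2cccc(Br)c2)c2ccc(C3CCCCC3)cc2)cc1` gives 8 nM in this assay.
Compound 3 `O=C(NC[C@@H](O)C(=O)O)c1ccc(CN(C(=O)Nc2ccccc2)c2ccc(C3=CCCCC3)cc2)cc1` gives 166 nM in this assay.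

Compound 2 has the lowest number of the three and stands as the most potent; compound 1 is nearest and compound 3 furthest, both beyond the scatter.

Compound 4 `O=C(NC[C@@H](O)C(=O)O)c1ccc(CN(C(=O)Nc2cc(Cl)cc(Cl)c2)c2ccc(C3CCCCC3)cc2)cc1` has not yet been measured. It differs from compound 2 by 3,5-dichlorophenyl in place of 3-bromophenyl on an amide-type nitrogen. Among the measured compounds shown here, no measured pair in this set shows this kind of change, so the expectation rests on compound 2 alone. The step from compound 2 to compound 4 is expected to be a 1.1-fold lower number from compound 2 to compound 4 (0.06 log units; within the scatter), none beyond the scatter. Compound 4 is estimated at 7 nM in this assay, with a range from 2.5 nM to 20 nM.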

Compound 4, half-maximal inhibitory concentration: 4 nM
Beside the measured number, compound 4's estimate is 1.8-fold (0.24 log units) above it; low and high end bracket the measured number.
By their numbers in this assay, from the lowest: compounds 4 and 2 (each within the scatter of the next); then compound 1; then compound 3.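

In this assay, 3,5-dichlorophenyl in place of 3-bromophenyl on an amide-type nitrogen gives a 2.0-fold lower number from compound 2 to compound 4 (0.30 log units; within the scatter) and so leaves the two compounds within the scatter of each other. Among the compounds shown here, this is the first pair here that differs in one place, and it shows that this site keeps a low number with two chlorine atoms as with one bromine atom. Nothing at hand explains this result.

On these data alone, whether an aryl ring carrying a nitrile or a methoxy group would hold the number at this site remains open. So does whether 3,5-dichlorophenyl would behave alike on the core of compound 1.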